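The source may report more compounds than this note shows. Statements on the series, on what has been measured and on what is new or still open speak of the compounds shown alone.

Within the data shown here, in a functional assay on NCI-H1993 cells (Homo sapiens) for inhibition, read by CCK-8 assay, with a stated time of 72 h (on this read-out lower numbers stand for stronger inhibition and higher numbers for weaker inhibition), compound 2 `Cn1nccc1-c1cnc2ncn(Cc3ccc4ncccc4c3)c2n1` gives 7910 nM and stands highest of the three numbers so far, while compound 1 `CC(c1cc2cccnc2cc1F)n1cnc2ncc(-c3ccccc3)nc21` at 570 nM and compound 3 `CC(c1cc2cccnc2cc1F)n1cnc2ncc(-c3cnc4ccccc4c3)nc21` at 109 nM lie lower. Compound 4 `c1cnc2ccc(Cn3cnc4ncc(-c5ccncc5)nc43)cc2c1` keeps the rest of compound 2 but carries pyridin-4-yl in place of 1-methyl-1H-pyrazol-5-yl on an aromatic carbon. Among the measured compounds shown here, the one measured step that swaps a group at this place is a 5.2-fold lower number from compound 1 to compound 3 (0.72 log units; beyond the scatter) and it puts quinolin-3-yl in place of phenyl, on compounds that also differ from compound 2 elsewhere. That step is only a loose guide, so a modest move toward a lower number is expected. The expected size is a 2.6-fold lower number from compound 2 to compound 4 (0.42 log units; beyond the scatter) on this read-out. For compound 4 the estimated value is 3000 nM (range 700 nM to 10000 nM).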

Compound 4, half-maximal inhibitory concentration: 1160 nM
For compound 4 the middle estimate is 2.6-fold (0.41 log units) above the measured one; the measured number falls inside the stated range.
By their numbers in this assay, from the lowest: compound 3; then compound 1; then compound 4; then compound 2.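

In this assay, putting pyridin-4-yl in place of 1-methyl-1H-pyrazol-5-yl gives a 6.8-fold lower number from compound 2 to compound 4 (0.83 log units; beyond the scatter), so the group at this aromatic carbon also matters on the core of compound 2, not only on that of compound 1. Both groups hold 6 heavy atoms, so this step comes with a change in ring size and ring nitrogen count, not in heavy-atom count. Nothing available explains the shift. Still open, on these data alone, is how an amine such as morpholine or a carboxylic acid at this carbon would read, and whether pyridin-4-yl would behave alike on the core of compound 1.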